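The source may report more compounds than this note shows. Statements on the series, on what has been measured and on what is new or still open speak of the compounds shown alone.

Measured so far in a functional assay on HL-60 cells (Homo sapiens) for antiproliferative activity, read by MTT assay, with a stated time of 72 h; a higher number here means a weaker inhibitor, a lower number a stronger inhibitor: compound 1 `CCC(=O)N(C)c1ccc2[nH]c(-c3n[nH]c4ccccc34)cc2n1` gives 6130 nM; compound 2 `CN(C(=O)c1ccccc1)c1ccc2[nH]c(-c3n[nH]c4ccccc34)cc2n1` gives 4850 nM; compound 3 `CN(C(=O)c1ccc(Cl)cc1)c1ccc2[nH]c(-c3n[nH]c4ccccc34)cc2n1` gives 450 nM.

Compound 2 stands second highest of the three numbers: a 1.3-fold lower number from compound 1 to compound 2 (0.10 log units; within the scatter) places it near compound 1, while an 11-fold lower number from compound 2 to compound 3 (1.03 log units; beyond the scatter) leaves it far from compound 3. Compound 4 `CN(C(=O)c1ccccc1)c1ccc2[nH]c(-c3n[nH]c4cc(Cl)ccc34)cc2n1` differs from compound 2 by chloro in place of hydrogen on an aromatic carbon. For the measured compounds named here, the one measured step that also adds chloro, an 11-fold lower number from compound 2 to compound 3 (1.03 log units; beyond the scatter), puts that chloro on another ring, so it bears only indirectly; no measured step touches the ring changed here. The expected step in this assay is therefore modest, a 1.6-fold lower number from compound 2 to compound 4 (0.21 log units; within the scatter), with a lean toward a lower number. Compound 4 is estimated at 3000 nM, within 900 nM to 10000 nM.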

Compound 4, half-maximal inhibitory concentration: 5620 nM
Compound 4: middle estimate off by 1.9-fold (0.27 log units), on the low side, within the range that was stated.
By their numbers in this assay, from the lowest: compound 3; then compounds 2, 4 and 1 (each within the scatter of the next).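

In this assay chloro in place of hydrogen on an aromatic carbon of the six-membered carbon-only ring of the fused system gives a 1.2-fold higher number from compound 2 to compound 4 (0.06 log units; within the scatter) and leaves compound 4 indistinguishable from compound 2. The same exchange on another ring gives an 11-fold lower number from compound 2 to compound 3 (1.03 log units; beyond the scatter) and shows that, in these compounds, the outcome of adding chloro depends on where it is placed. Nothing available explains this contrast. Going by these compounds, whether an amine or a methoxy group at this position would match chloro remains open, as does the outcome of chloro on the other carbons of this ring.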